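The compounds below may be only part of what the source reports. "The series", "measured", "known", "first", "only" and "open" are said of these compounds alone.

In a functional assay on HeLa cells (Homo sapiens) for antiproliferative activity, read by MTT assay, with a stated time of 24 h (on this read-out higher numbers stand for weaker inhibition and lower numbers for stronger inhibition), compound 1 `c1ccc(Cc2nnc(Cn3nnc4ccccc43)o2)cc1` gives 167000 nM, compound 2 `Brc1ccc(Cc2nnc(Cn3nnc4ccccc43)o2)cc1` gives 198000 nM and compound 3 `Brc1cccc(-c2nnc(Cn3nnc4ccccc43)o2)c1` gives 301000 nM. These three values lie within the scatter of one another, so compound 3 stands level with the other two. Compound 4 `Brc1ccc(-c2nnc(Cn3nnc4ccccc43)o2)cc1` has the same atoms as compound 3, joined differently: 4-bromophenyl in place of 3-bromophenyl on an aromatic carbon, with 4-bromophenyl in place of 3-bromophenyl on an aromatic carbon. Within the data shown here, two measured steps bear on this change. Bromo in place of hydrogen gave a 1.2-fold higher number from compound 1 to compound 2 (0.07 log units; within the scatter), and 3-bromophenyl in place of benzyl gave a 1.8-fold higher number from compound 1 to compound 3 (0.26 log units; within the scatter). Both stay within the scatter, so no step beyond it is expected in this assay, in either direction. The expected step is small, a 1.2-fold lower number from compound 3 to compound 4 (0.08 log units; within the scatter). For compound 4 the estimated value is 250000 nM, with an expected range from 130000 nM to 480000 nM.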

Compound 4, half-maximal inhibitory concentration: 305000 nM
Estimate against measurement, compound 4: 1.2-fold (0.09 log units) below; measured number inside the range.
By their numbers in this assay, from the lowest: compounds 1, 2, 3 and 4 (each within the scatter of the next).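

Putting 4-bromophenyl in place of 3-bromophenyl on this aromatic carbon gives a 1.0-fold higher number from compound 3 to compound 4 (0.01 log units; within the scatter) in this assay, so for this pair, where the bromine sits on the phenyl ring makes no difference that can be told from the scatter. Replacing benzyl with 4-bromophenyl gives a 1.8-fold higher number from compound 1 to compound 4 (0.26 log units; within the scatter) and also stays within the scatter, as the change to 3-bromophenyl did. On these data alone, whether an amine or a carboxylic acid in place of the bromo group would shift the number beyond the scatter remains open. Nothing available explains why these compounds sit level.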